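The source may hold more compounds than are shown below. What is called first, only, known or untested is meant among the compounds shown, and "the series" means these compounds.

Measured so far in a physicochemical assay for solubility, read by HPLC, with a stated time of 4 h, at pH 2, tested at 10 mg/mL; on this read-out lower numbers stand for lower solubility and higher numbers for higher solubility:
compound 1 `Cc1cc(CCC#N)cc(C)c1Oc1cc(Nc2ccc(C#N)cc2)c(N)cc1C(=O)N(C)C` gives 65.1 ug/mL;
compound 2 `CCNC(=O)c1cc(N)c(Nc2ccc(C#N)cc2)cc1Oc1c(C)cc(CCC#N)cc1C` gives 69.4 ug/mL;
compound 3 `Cc1cc(CCC#N)cc(C)c1Oc1cc(Nc2ccc(C#N)cc2)c(N)cc1C(=O)NC1CC1` gives 141 ug/mL.

Compound 3 has the highest number of the three: a 2.2-fold higher number from compound 1 to compound 3 (0.34 log units; beyond the scatter) and a 2.0-fold higher number from compound 2 to compound 3 (0.31 log units; beyond the scatter) are both beyond the scatter, whereas a 1.1-fold higher number from compound 1 to compound 2 (0.03 log units; within the scatter) lies within it. Compound 4 `Cc1cc(CCC#N)cc(C)c1Oc1cc(Nc2ccc(C#N)cc2)c(N)cc1COC(=O)C1CC1` follows from compound 3 by a change of a different kind: ((cyclopropylcarbonyl)oxy)methyl in place of cyclopropylcarbamoyl on an aromatic carbon. Within the data shown here, none of the measured steps bears directly on it; all three exchange only the group on the amide-type nitrogen, and each stayed modest or within the scatter in this assay. With no measured guide for an exchange of this kind, the expected step of a 2.4-fold lower number from compound 3 to compound 4 (0.37 log units; beyond the scatter) is small and uncertain in direction. Compound 4 is therefore estimated at 60 ug/mL, with a range from 15 ug/mL to 250 ug/mL.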

Compound 4, solubility: 1.24 ug/mL
The estimate for compound 4 lay 48-fold (1.68 log units) above the measured number, outside the stated range (below it).
By their numbers in this assay, from the lowest: compound 4; then compounds 1 and 2 (each within the scatter of the next); then compound 3.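

In this assay, among these compounds, the earlier steps, which changed only the group on the amide-type nitrogen, stayed modest or within the scatter, yet replacing the whole carbamoyl group on this aromatic carbon with ((cyclopropylcarbonyl)oxy)methyl gives a 110-fold lower number from compound 3 to compound 4 (2.06 log units; beyond the scatter) in this series. The same kind of exchange gives a 56-fold lower number from compound 2 to compound 4 (1.75 log units; beyond the scatter) and a 53-fold lower number from compound 1 to compound 4 (1.72 log units; beyond the scatter), so this position responds far more to the change of the whole group than to changes on the nitrogen. Nothing measured here explains the fall.

From the compounds shown here alone, what a carboxylic acid or an aminomethyl group on this aromatic carbon would give remains open.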